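A few compounds are considered here, and "the series" means these few. Any claim that something is new, unique, unknown or untested is made for them only; others in the source may bear on it.

In a functional assay on U-373MG ATCC cells (Homo sapiens) for inhibition, read by MTT assay, with a stated time of 72 h (a lower number here means a stronger inhibitor, a higher number a weaker inhibitor), three compounds sharing one core have been measured. Compound 1 `COc1ccc(NC(=S)NC2CC(C)(C)Oc3ccc(Br)cc32)cc1` gives 40000 nM, compound 2 `CC1(C)CC(NC(=S)Nc2cccc(C#N)c2)c2cc(Br)ccc2O1` gives 6000 nM, and compound 3 `COc1cccc(NC(=S)NC2CC(C)(C)Oc3ccc(Br)cc32)c1` gives 66000 nM. Compound 3 therefore sits at the weak end of this small set, alongside compound 1 rather than clearly apart from it. Putting 3-methoxyphenyl in place of 4-methoxyphenyl gives a 1.7-fold higher number from compound 1 to compound 3 (0.22 log units; within the scatter), whereas putting methoxy in place of cyano on an aromatic carbon gives an 11-fold higher number from compound 2 to compound 3 (1.04 log units; beyond the scatter).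

The next compound, compound 4 `CC1(C)CC(NC(=S)NCc2ccccc2)c2cc(Br)ccc2O1`, keeps the core and changes one group: benzyl in place of 3-methoxyphenyl on an amide-type nitrogen. Here benzyl replaces 3-methoxyphenyl on an amide-type nitrogen. For the measured compounds named here, no measured compound carries benzyl, so no measured step shows this change directly. The closest guides are changes at that same nitrogen. One is the small step above, and the other is larger: a 6.7-fold lower number from compound 1 to compound 2 (0.82 log units; beyond the scatter). Going by the values given here, with only three compounds, these steps give a rough guide at best, and they suggest no large change. A modest lean towards a lower number is expected, as compound 3 stands at 66000 nM and compound 2 shows a lower number is reachable at 6000 nM. The expected step in this assay is a 1.9-fold lower number from compound 3 to compound 4 (0.28 log units; within the scatter), so no change beyond the scatter is expected. For compound 4, the estimated value is 35000 nM, with an expected range of 12000 nM to 85000 nM.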

Compound 4, half-maximal inhibitory concentration: 29000 nM
For compound 4 the middle estimate is 1.2-fold (0.08 log units) above the measured one, within the range that was stated.
By their numbers in this assay, from the lowest: compound 2; then compounds 4, 1 and 3 (each within the scatter of the next, the first and the last beyond it).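

In this assay, for the compounds shown here, benzyl is the first group at this nitrogen that is not a substituted phenyl, and it carries no oxygen, so the change removes the methoxy group's hydrogen-bond acceptor; this gives a 2.3-fold lower number from compound 3 to compound 4 (0.36 log units; beyond the scatter), a modest gain, while the swap from 4-methoxyphenyl gives a 1.4-fold lower number from compound 1 to compound 4 (0.14 log units; within the scatter), which stays within the scatter, so a methoxy group is not needed to reach this level. Benzyl still falls short of 3-cyanophenyl, with a 4.8-fold higher number from compound 2 to compound 4 (0.68 log units; beyond the scatter), which leaves compound 2 as the only one of the four whose steps to all the others lie beyond the scatter. Nothing given here accounts for these differences.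

Going by these compounds, what stays open is whether the advantage of compound 2 belongs to the nitrile itself, which a 4-cyanophenyl group or a cyano group on the benzyl ring would help to test, and how a longer chain such as 2-phenylethyl or an amine on this nitrogen would behave. On these data alone, the bromine and the thiocarbonyl are also common to all four compounds, so the effect of replacing bromine with chlorine, or the thiocarbonyl with a carbonyl, remains unknown.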